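Amide-bearing piperidine replaces the basic side chain

The source may report more compounds than this note shows. Statements on the series, on what has been measured and on what is new or still open speak of the compounds shown alone.

Compound 1 `COc1cc2nc(NCc3ccccc3)nc(NC3CCCCCC3)c2cc1OC` and compound 2 `COc1cc2nc(N3CCC(Cc4ccccc4)CC3)nc(NC3CCCCCC3)c2cc1OC` share their core with compound 3 `COc1cc2nc(NCCN3CCCCC3)nc(NC3CCCCCC3)c2cc1OC`. In an in vitro assay on B300-19 cells for displacement of a labelled ligand from C-C chemokine receptor type 4 (Homo sapiens), tested at 1 uM (a higher number here means more inhibition at the concentration tested (going by the name of the read-out), a lower number less inhibition), compound 1 reaches only a limit, < 0%. Compound 2 likewise gives a limit in this assay, < 0%. Within the data shown here, compound 3 gives 18% in this assay, the only number among the three, the other two sitting at the limit of < 0% in this assay, at which 2 of the 3 values shown sit. Among the measured compounds shown here, the single measurable step, a number at least 18 percentage points higher from compound 1 to compound 3 (beyond the scatter), shows that the basic chain end lifts the read-out from the limit.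

Compound 4 `COc1cc2nc(N3CCC(C(N)=O)CC3)nc(NC3CCCCCC3)c2cc1OC` is not yet measured and differs from compound 3 in one place: 4-carbamoylpiperidin-1-yl in place of (2-(piperidin-1-yl)ethyl)amino on an aromatic carbon. The step into compound 3 bears on this only loosely, as it changed the chain end while keeping the chain; compound 4 removes the chain and attaches the ring directly. Compound 2 also carries a directly attached piperidinyl ring, and in this assay compound 2 sits at the limit, < 0%. For the measured compounds named here, no step to compound 4 has been measured. Compound 4 is therefore expected to fall back, with a number 13 percentage points lower from compound 3 to compound 4 (beyond the scatter) as the expected step. The estimate for compound 4 in this assay is 5%, expected between 0% and 20%.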

Compound 4, a percentage reported as inhibition, at one concentration (the size of the read-out at that concentration, not a potency): < 0%
Compound 4 gave a limit, no number (the forecaster's own chance of this, stated with the estimate: 50%); middle value at least 5 percentage points from the limit.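

Putting 4-carbamoylpiperidin-1-yl in place of (2-(piperidin-1-yl)ethyl)amino on the aromatic carbon between two ring nitrogen atoms gives a number at least 18 percentage points lower from compound 3 to compound 4 (beyond the scatter) in this assay. The two groups match in heavy atom count and in hydrogen-bond donors and acceptors as counted, and neither carries a net charge, so these counts alone do not separate compound 3 from compound 4. The steps from compound 1 and from compound 2 to compound 4 cannot be read, with a limit at both ends, and only compound 3 gives a number in the series: the limit of < 0% in this assay, at which 3 of the 4 values shown sit.

On these data alone, it remains open whether the read-out of compound 3 depends on the piperidin-1-yl chain end, the chain or the amino link. A longer chain ending in piperidin-1-yl, or a 4-(aminomethyl)piperidin-1-yl group, would bear on this.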